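The source may hold more compounds than are shown below. What is called first, only, known or untested is meant among the compounds shown, and "the series" means these compounds.

Within the data shown here, compound 2 `CCN(CC)C(=O)CN(c1ccc(C)cc1)S(=O)(=O)c1ccccc1C` is the stronger of the two compounds measured so far in a functional assay on CHO cells for inhibition of Orexin receptor type 2 (Homo sapiens), read by FLIPR and calcium flux (on this read-out lower numbers stand for stronger inhibition and higher numbers for weaker inhibition), where compound 2 gives 58 nM. Among the measured compounds shown here, its only neighbour is compound 1 `CCN(CC)C(=O)CN(c1ccc(C)cc1)S(=O)(=O)c1cccc(F)c1`, and in this assay compound 1 gives 839 nM. For the measured compounds named here, the single measured step between them, a 14-fold lower number from compound 1 to compound 2 (1.16 log units; beyond the scatter), is the one structural change on record, and it concerns the same place in the molecule as the change now considered.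

Compound 3 `CCN(CC)C(=O)CN(c1ccc(C)cc1)S(=O)(=O)c1ccc(Br)cc1` differs from compound 2 in exactly that place: 4-bromophenyl in place of 2-methylphenyl on a sulfonyl sulfur. Going by the values given here, no measured step covers this particular exchange. Among the compounds with values here, what can be said is that the one aryl group carrying a halogen, in compound 1, gave the weaker result, while the methyl-bearing ring of compound 2 gave the stronger one; the ring of compound 3 again carries a halogen, bromine, though the group is not the one seen in compound 1. The size of the step from compound 2 is therefore uncertain, and the expectation is a weakening that is probably beyond the scatter, estimated as a 5.2-fold higher number from compound 2 to compound 3 (0.71 log units; beyond the scatter). For compound 3 the estimated value in this assay is 300 nM, with a range from 80 nM to 1200 nM.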

Compound 3, half-maximal inhibitory concentration: 142 nM
For compound 3 the middle estimate is 2.1-fold (0.32 log units) above the measured one; the measured number falls inside the stated range.
By their numbers in this assay, from the lowest: compound 2; then compound 3; then compound 1.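

With a third aryl group on a sulfonyl sulfur whose other neighbour is the sulfonamide nitrogen, the read-out in this assay now spreads over three separate levels rather than two: the exchange of 2-methylphenyl for 4-bromophenyl gives a 2.4-fold higher number from compound 2 to compound 3 (0.39 log units; beyond the scatter), while the exchange of 3-fluorophenyl for 4-bromophenyl gives a 5.9-fold lower number from compound 1 to compound 3 (0.77 log units; beyond the scatter). A halogen on this ring therefore does not by itself place a compound at the weak end of the series, as compound 1 and compound 3 both carry one and yet stand apart, although compound 2, which carries none, remains the strongest of the three. No supporting data bear on why these aryl groups fall in this order.

Fluorine and bromine differ both in identity and in their place on the ring, so these compounds cannot show which of the two separates compound 1 from compound 3, nor whether the methyl group of compound 2 or its place on the ring matters more. Also open, on these data alone, is how this position responds to groups of another kind, such as a methoxy group, an amine or a carboxylic acid on the ring, and how changes to the rest of the core, shared by all three compounds, would read.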